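The compounds below may be only part of what the source reports. "The series", "measured", "known", "first", "only" and "open" are said of these compounds alone.

Measured compounds:
Compound 1 `COc1ccc(C)cc1-c1c(C)nn(-c2nc(-c3ccc(Cl)c(Cl)c3)c(SC(C)C)s2)c1C(=O)O`: 9500 nM
Compound 2 `Cc1nn(-c2nc(-c3ccc(Cl)c(Cl)c3)c(SC(C)C)s2)c(C(=O)O)c1-c1cncnc1`: 22000 nM
Compound 3 `Cc1nn(-c2nc(-c3ccc(Cl)c(Cl)c3)c(SC(C)C)s2)c(C(=O)O)c1-c1cccc(Cl)c1C`: 5100 nM

All three share one core and differ only in the aryl group on the five-membered ring. In a functional assay on BJAB cells (Homo sapiens) for antiproliferative activity, with a stated time of 4 days (a higher number here means that more compound is needed for the effect, a lower number that less compound is needed), compound 1 stands second highest of the three numbers; its nearest neighbour is compound 3, reached by a 1.9-fold lower number from compound 1 to compound 3 (0.27 log units; within the scatter), and its furthest is compound 2, reached by a 2.3-fold higher number from compound 1 to compound 2 (0.36 log units; beyond the scatter).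

Compound 4 `Cc1cc(-c2c(C)nn(-c3nc(-c4ccc(Cl)c(Cl)c4)c(SC(C)C)s3)c2C(=O)O)cc(C)n1` has not yet been measured. It differs from compound 1 in one place: 2,6-dimethylpyridin-4-yl in place of 2-methoxy-5-methylphenyl on an aromatic carbon

Going by the values given here, two measured steps bear on this change. Exchanging the 2-methoxy-5-methylphenyl group for a six-membered aromatic ring with nitrogen gave a 2.3-fold higher number from compound 1 to compound 2 (0.36 log units; beyond the scatter), whereas exchanging it for another carbon-only ring gave a 1.9-fold lower number from compound 1 to compound 3 (0.27 log units; within the scatter). The group entering compound 4 is again a ring with one hetero atom, though it carries two methyl groups. Compound 4 is therefore expected to show a 1.4-fold higher number from compound 1 to compound 4 (0.14 log units; within the scatter), a modest shift towards a higher number, if any beyond the scatter. The estimate for compound 4 in this assay is 13000 nM, with a range from 5500 nM to 32000 nM.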

Compound 4, half-maximal effective concentration: 580 nM
Compound 4: middle estimate off by 22-fold (1.35 log units), on the high side; measured number outside the range, below it.
By their numbers in this assay, from the lowest: compound 4; then compounds 3 and 1 (each within the scatter of the next); then compound 2.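

In this assay, placing 2,6-dimethylpyridin-4-yl on this aromatic carbon gave a 16-fold lower number from compound 1 to compound 4 (1.21 log units; beyond the scatter) and also an 8.8-fold lower number from compound 3 to compound 4 (0.94 log units; beyond the scatter) and a 38-fold lower number from compound 2 to compound 4 (1.58 log units; beyond the scatter) on the same change of aryl group. The earlier compounds shown here gave no hint of a step this large here, and a ring with nitrogen now proves not to be tied to a higher number, as compound 2 with pyrimidin-5-yl has the highest number of the set and compound 4 the lowest. Nothing available here explains this gain. On these data alone, how a plain pyridin-4-yl group, without the two methyl groups, would compare remains open, so the shares of the ring nitrogen and the methyl groups in this step cannot be separated. Equally open, as far as these compounds go, is whether an amino group in place of either methyl group would keep the low number.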